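A few compounds are considered here, and "the series" means these few. Any claim that something is new, unique, unknown or untested is made for them only; others in the source may bear on it.

Series notes. In a functional assay on A549 cells (Homo sapiens) for cytotoxicity, read by sulforhodamine B assay, with a stated time of 48 h (a lower number here means a stronger inhibitor, a higher number a weaker inhibitor), compound 1 (`COc1ccc(/C=C/C(=O)c2cccc(-c3ccc(F)cc3)c2)cc1`) gives 11200 nM and compound 2 (`COc1ccc(/C=C/C(=O)c2cccc(Br)c2)cc1OC`) gives 9430 nM so these two stand within the scatter of each other and cannot be ranked. Compound 3 (`COc1ccc(/C=C/C(=O)c2cccc(Br)c2)cc1`) is compound 2 with hydrogen in place of methoxy on an aromatic carbon. Going by the values given here, no measured pair isolates this change, so this assay offers no direct step to carry over. The expectation rests on two readings. Compound 1 also has hydrogen at that place, though it differs elsewhere, and it reads 11200 nM while compound 2 reads 9430 nM with no gap beyond the scatter. With only these two values the evidence is thin, and the range is kept wide in both directions. No step beyond the scatter is expected, and the estimated move is a 1.1-fold higher number from compound 2 to compound 3 (0.03 log units; within the scatter) on that basis. For compound 3 the expected value is 10000 nM with an estimated range of 4000 nM to 25000 nM as a working figure.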

Compound 3, half-maximal inhibitory concentration: 34200 nM
The estimate for compound 3 lay 3.4-fold (0.53 log units) below the measured number, outside the stated range (above it).
By their numbers in this assay, from the lowest: compounds 2 and 1 (each within the scatter of the next); then compound 3.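

Taken as a single change, hydrogen in place of methoxy on an aromatic carbon, ortho to a methoxy group, gives a 3.6-fold higher number from compound 2 to compound 3 (0.56 log units; beyond the scatter) in this assay, so this place is not indifferent to the change, as the two earlier compounds alone could not show. With that hydrogen held constant, bromo in place of 4-fluorophenyl on an aromatic carbon gives a 3.1-fold higher number from compound 1 to compound 3 (0.48 log units; beyond the scatter), so the number also responds to the group at this second place, and the closeness of compound 1 and compound 2 conceals two separate single-place differences. Nothing shown accounts for either step.

The compounds shown leave open whether the shift at the first place belongs to methoxy itself or would also appear with a hydroxy group, an ethoxy group or an amine there. They also leave open whether the two single-place steps add up, which would take a compound carrying both methoxy groups together with the 4-fluorophenyl group on the shared core.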